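Moving the Methyl on the Benzyl Group

The source may report more compounds than this note shows. Statements on the series, on what has been measured and on what is new or still open speak of the compounds shown alone.

Of the compounds shown here, two have so far been measured in an assay for inhibition of Amine oxidase [flavin-containing] A (Rattus norvegicus); a lower number here means a stronger inhibitor, a higher number a weaker inhibitor. Compound 2 `Cc1cccc(COc2ccc(-c3nn(CCC#N)c(=S)o3)cc2)c1` gives 14000 nM, and compound 1 `COc1cccc(COc2ccc(-c3nn(CCC#N)c(=S)o3)cc2)c1` gives 8100 nM; compound 2 stands at one end of these two numbers, yet compound 1 lies within the scatter of it. Within the data shown here, the only measured step is a 1.7-fold higher number from compound 1 to compound 2 (0.24 log units; within the scatter), a methyl in place of methoxy on an aromatic carbon.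

Compound 3 `Cc1ccc(COc2ccc(-c3nn(CCC#N)c(=S)o3)cc2)cc1` has not been measured in this assay. It differs from compound 2 by 4-methylphenyl in place of 3-methylphenyl on a saturated chain carbon bound to an oxygen on an aromatic ring. Among the measured compounds shown here, no measured step follows this kind of rearrangement: the one step that exists exchanges one group for another rather than moving a group, and it stayed within the scatter. Nothing therefore points to a shift in either direction, and the expected step from compound 2 to compound 3 in this assay is no change at the digits printed from compound 2 to compound 3 (within the scatter), none beyond the scatter. Compound 3 is accordingly estimated at 14000 nM in this assay, with an expected range from 5000 nM to 40000 nM.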

Compound 3, half-maximal inhibitory concentration: 10000 nM
For compound 3 the middle estimate is 1.4-fold (0.15 log units) above the measured one, and the stated range covers the measured number.
By their numbers in this assay, from the lowest: compounds 1, 3 and 2 (each within the scatter of the next).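

Among these compounds, compound 3 gives the first reading in which the methyl stays on the benzyl group and only its place changes. In this assay, 4-methylphenyl in place of 3-methylphenyl on a saturated chain carbon bound to an oxygen on an aromatic ring gives a 1.4-fold lower number from compound 2 to compound 3 (0.15 log units; within the scatter), so this assay does not tell the two methyl placements apart. Exchanging the group and moving it in one change, 4-methylphenyl in place of 3-methoxyphenyl, gives a 1.2-fold higher number from compound 1 to compound 3 (0.09 log units; within the scatter), which leaves all three compounds within the scatter of one another, and no other evidence bearing on this result is available.

The compounds shown leave open whether any group on this phenyl ring can shift the number beyond the scatter, for instance an amine or a carboxylic acid in place of the methyl, or a benzyl group carrying no methyl at all. As far as these compounds go, the cyanoethyl chain on the shared core is also the same in all three compounds, so the effect of a longer chain or an amide in place of the nitrile remains unknown.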